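The source may hold more compounds than are shown below. What is called first, only, known or untested is meant among the compounds shown, and "the series" means these compounds.

Compound 1 `CN(C)CCCNc1ncnc2c1C(=O)C(N1CCCCC1)=CC2=O`: 1170 nM
Compound 2 `CCCC(=O)OCCNc1ncnc2c1C(=O)C(OC)=CC2=O`: 2660 nM
Compound 3 `COC1=CC(=O)c2ncnc(OCCOCCOCCO)c2C1=O`: > 29600 nM (a limit, not a number)

All three compounds were tested in a functional assay on L1210 cells (Mus musculus) for inhibition; on this read-out higher numbers stand for weaker inhibition and lower numbers for stronger inhibition. Of the two compounds with an actual number, compound 2 has the higher one at 2660 nM, which means weaker inhibition. Its nearest neighbour is compound 1 at 1170 nM, and that gap lies beyond the usual scatter. Compound 3 reports only a limit of > 29600 nM, so it cannot be placed exactly.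

The next compound to test is compound 4 `COC1=CC(=O)c2ncnc(NCCN(C)C)c2C1=O`, which differs from compound 2 in one place: dimethylamino in place of (propylcarbonyl)oxy on a saturated chain carbon, two bonds along the chain from a nitrogen on an aromatic ring. In words, dimethylamino stands in place of (propylcarbonyl)oxy on a saturated chain carbon, two bonds along the chain from a nitrogen on an aromatic ring.

Among the compounds with values here, no measured pair of compounds shows this change alone, so any forecast is tentative. Within the data shown here, the only guide is compound 1, which also carries dimethylamino, though its structure is not otherwise the same, and which gives 1170 nM. That points to a moderate move toward stronger inhibition in this assay. The expected change is a 2.4-fold lower number from compound 2 to compound 4 (0.38 log units; beyond the scatter). For compound 4 the estimated value is 1100 nM, with an expected range from 300 nM to 4000 nM.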

Compound 4, half-maximal inhibitory concentration: 1140 nM
Beside the measured number, compound 4's estimate is 1.0-fold (0.02 log units) below it; measured number inside the range.
By their numbers in this assay, from the lowest: compounds 4 and 1 (each within the scatter of the next); then compound 2. At a limit, above all of these: compound 3.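

Within the data shown here, this pair gives the first direct reading of this position. With the rest of the molecule unchanged, dimethylamino in place of (propylcarbonyl)oxy on a saturated chain carbon, two bonds along the chain from a nitrogen on an aromatic ring, gives in this assay a 2.3-fold lower number from compound 2 to compound 4 (0.37 log units; beyond the scatter), a modest step toward stronger inhibition. Inhibition in these cells therefore survives an exchange of two quite different end groups, one made only of carbon and oxygen and the other carrying a nitrogen, although a single step cannot tell which feature of the exchange moves the number, and nothing measured here bears on a cause.

As far as these compounds go, it remains open whether this gain is specific to dimethylamino or whether a primary amine or a morpholine on the same chain carbon would read alike, and a carboxylic acid there would test whether a nitrogen is needed at all. Among these compounds, it is also open whether the same exchange would give a step of similar size on a different core, since only one pair speaks to it so far.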